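This account rests on a few compounds, and the source may have more. Where it says the series, first, only, none or still open, it means among the compounds named here.

Measured in a functional assay on MCF7 cells (Homo sapiens) for antiproliferative activity, read by MTT assay, with a stated time of 48 h; on this read-out lower numbers stand for stronger inhibition and higher numbers for weaker inhibition:
- Compound 1 `COc1ccc(-c2c(Nc3ccc(F)cc3)c3ccccc3oc2=O)cc1`: 38500 nM
- Compound 2 `COc1ccc(-c2c(Nc3cccc(C(F)(F)F)c3)c3ccccc3oc2=O)cc1`: 21600 nM
- Compound 3 `COc1ccc(-c2c(Nc3ccc(F)cc3)c3ccc(OC)cc3oc2=O)cc1`: > 100000 nM

Compound 3 gives a limit of the assay and not a number. It stands at the limit of > 100000 nM in this assay, at which 1 of the 3 values shown sits.

Compound 4 `COc1ccc(-c2c(Nc3ccc(C)cc3)c3ccc(OC)cc3oc2=O)cc1` differs from compound 3 by one change: methyl in place of fluoro on an aromatic carbon, para to a large group (methyl in place of fluoro on an aromatic carbon). Within the data shown here, two measured steps bear on this. The swap of the group on nitrogen, a 1.8-fold lower number from compound 1 to compound 2 (0.25 log units; within the scatter), is a different replacement, but it shows that a change on this ring moved this assay little. The step that added methoxy, an at least 2.5-fold higher number from compound 1 to compound 3 (0.41 log units; beyond the scatter), went beyond the scatter, and compound 4 keeps that methoxy. A recovery of activity therefore seems unlikely, and no step beyond the scatter is expected. The expected step is a number no higher from compound 3 to compound 4 (the limit leaves the size open). Compound 4 is estimated at 100000 nM, with an expected range of 35000 nM to 280000 nM. A reported limit instead of a number would be no surprise.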

Compound 4, half-maximal inhibitory concentration: 66900 nM
For compound 4 the middle estimate is 1.5-fold (0.17 log units) above the measured one; the measured number falls inside the stated range.
By their numbers in this assay, from the lowest: compounds 2, 1 and 4 (each within the scatter of the next, the first and the last beyond it). At a limit, above all of these: compound 3.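

In this assay, methyl in place of fluoro, on an aromatic carbon para to a large group, gives an at least 1.4-fold lower number from compound 3 to compound 4 (0.17 log units; that floor lies within the scatter). With the added methoxy still in place, this position can therefore yield a measured value, as compound 4 does at 66900 nM. The floor of this step nevertheless lies within the scatter, and a real gain cannot be claimed. Compound 3 gives a limit and not a number, so the full size of the step stays unknown: the limit of > 100000 nM in this assay, at which 1 of the 4 values shown sits.

The compounds shown leave open whether 4-methylphenyl in place of 4-fluorophenyl would move the number in the same way on the core of compound 1. Also open, going by these compounds, is how this assay would respond to an amine, a carboxylic acid or a longer chain at this position.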